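Working notes: adding a methoxy to compound 2

This account rests on a few compounds, and the source may have more. Where it says the series, first, only, none or still open, it means among the compounds named here.

Measured in an ADME assay on LLC-MK2 cells (Macaca mulatta) for cytotoxicity, read by MTT assay, with a stated time of 48 h (on this read-out higher numbers stand for lower toxicity in this test and lower numbers for higher toxicity in this test), so far
- compound 1 `COc1ccc(/C=C/C(=O)/C(C)=C/c2ccccc2)cc1` gives 93000 nM in this series
- compound 2 `COc1ccc(/C=C(\C)C(=O)/C=C/c2ccccc2)cc1` gives 44000 nM in this series

Of the two measured compounds, compound 2 at 44000 nM holds the lower number, and the gap to compound 1 lies beyond the usual scatter. Compound 2 is therefore the more toxic of this pair in this assay on the present data.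

The next compound is compound 3 `COc1ccc(/C=C/C(=O)/C(C)=C/c2ccc(OC)cc2)cc1`, which differs from compound 2 by methoxy in place of hydrogen on an aromatic carbon of a six-membered ring. Among the compounds with values here, no measured pair shows this kind of change, so the expectation rests on little. No step beyond the scatter is expected in this assay, and neither direction is favoured. The expected change is a 1.1-fold lower number from compound 2 to compound 3 (0.04 log units; within the scatter) and remains an estimate only. Compound 3 is expected at 40000 nM in this assay with an estimated range from 15000 nM to 100000 nM around that figure.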

Compound 3, half-maximal cytotoxic concentration: 75000 nM
Beside the measured number, compound 3's estimate is 1.9-fold (0.27 log units) below it, within the range that was stated.
By their numbers in this assay, from the lowest: compounds 2, 3 and 1 (each within the scatter of the next, the first and the last beyond it).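

In this assay, methoxy in place of hydrogen on an aromatic carbon, para to a large group, gives a 1.7-fold higher number from compound 2 to compound 3 (0.23 log units; within the scatter) and a 1.2-fold lower number from compound 1 to compound 3 (0.09 log units; within the scatter). This position therefore accepts methoxy with no step beyond the scatter against either earlier compound, something the first two compounds could not show, as neither pair before held this change. Nothing available accounts for either step.

On these data alone, whether this tolerance holds only for methoxy stays open, as an amine, a carboxylic acid or a longer chain such as butoxy at the same place could behave differently. Compound 3 lies within the scatter of both compound 1 and compound 2, so it also leaves the gap between those two unexplained.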